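Moving the methoxy pair around the anilino ring

This account rests on a few compounds, and the source may have more. Where it says the series, first, only, none or still open, it means among the compounds named here.

Compound 1 `CC(C)CCn1cnc2c(Nc3cccc(O)c3)nc(N[C@H]3CC[C@H](N)CC3)nc21`: 60 nM
Compound 2 `COc1ccc(Nc2nc(N[C@H]3CC[C@H](N)CC3)nc3c2ncn3CCC(C)C)c(OC)c1`: 630 nM

In a functional assay on EOL1 cells (Homo sapiens) for inhibition, read by fluorescence, with a stated time of 72 h (a lower number here means a stronger inhibitor of growth, a higher number a weaker inhibitor of growth), compound 2 stands at the higher of the two numbers, with compound 1 sitting well below it. Compound 3 `COc1cc(Nc2nc(N[C@H]3CC[C@H](N)CC3)nc3c2ncn3CCC(C)C)cc(OC)c1` differs from compound 2 by 3,5-dimethoxyphenyl in place of 2,4-dimethoxyphenyl on a nitrogen on an aromatic ring. Going by the values given here, the only measured step, an 11-fold higher number from compound 1 to compound 2 (1.02 log units; beyond the scatter), changes both the kind and the placement of the substituents at once, so it bears on this step only loosely; no step moves methoxy groups alone. With no direct guide, the expected change is small: a 1.6-fold lower number from compound 2 to compound 3 (0.20 log units; within the scatter) is the estimate. Compound 3 is therefore expected near 400 nM, within 150 nM to 1500 nM.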

Compound 3, concentration for 50% growth inhibition: 140 nM
For compound 3 the middle estimate is 2.9-fold (0.46 log units) above the measured one, and the stated range ends above it.
By their numbers in this assay, from the lowest: compound 1; then compound 3; then compound 2.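

In this assay placement alone matters at this position: the two methoxy groups, moved from 2,4-dimethoxyphenyl to 3,5-dimethoxyphenyl, give a 4.5-fold lower number from compound 2 to compound 3 (0.65 log units; beyond the scatter) with the atoms unchanged. Even so, the 3,5-dimethoxyphenyl group does not fully match the 3-hydroxyphenyl group, as a 2.3-fold higher number from compound 1 to compound 3 (0.37 log units; beyond the scatter) shows for the exchange of one for the other. Nothing measured here explains either step. What the compounds shown leave open is how a single methoxy group, an amine or a carboxylic acid on this ring would compare with compound 1.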